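Shrinking the Ring on the Amide-Type Nitrogen

The source may hold more compounds than are shown below. What is called first, only, known or untested is meant among the compounds shown, and "the series" means these compounds.

Three compounds sharing one core differ only in the group on an amide-type nitrogen in a ring. Compound 1 `O=C(O)c1cc(-c2cccc(COc3ccc4c(c3)CN(c3ccccc3)C4=O)c2)ccc1Cl` carries a phenyl there and gives 260 nM in an assay on HEK293 cells for positive allosteric modulation of metabotropic glutamate receptor 2 (Rattus norvegicus), read by thallium flux; a lower number here means that less compound is needed, a higher number that more compound is needed for the effect. Compound 2 `O=C(O)c1cc(-c2cccc(COc3ccc4c(c3)CN(Cc3ccc(C(F)(F)F)cc3)C4=O)c2)ccc1Cl` gives 350 nM in this assay; the step of a 1.3-fold higher number from compound 1 to compound 2 (0.13 log units; within the scatter) lies within the scatter. Compound 3 `O=C(O)c1cc(-c2cccc(COc3ccc4c(c3)CN(C3CCC3)C4=O)c2)ccc1Cl`, with cyclobutyl in that place, gives 90 nM in this assay and stands lowest of the three: a 2.9-fold lower number from compound 1 to compound 3 (0.46 log units; beyond the scatter) and a 3.9-fold lower number from compound 2 to compound 3 (0.59 log units; beyond the scatter) are both modest steps beyond the scatter.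

Compound 4 `O=C(O)c1cc(-c2cccc(COc3ccc4c(c3)CN(C3CC3)C4=O)c2)ccc1Cl` differs from compound 3 by cyclopropyl in place of cyclobutyl on an amide-type nitrogen in a ring. Among the compounds with values here, the measured steps all concern the exchange of an aromatic group for cyclobutyl; no measured step compares two small non-aromatic rings of this kind with each other. Those steps show only that cyclobutyl gives the lowest number seen here. The exchange of cyclobutyl for cyclopropyl is expected to give a step no larger than the scatter, a 1.3-fold higher number from compound 3 to compound 4 (0.12 log units; within the scatter). Compound 4 is therefore expected to give about 120 nM in this assay, with a range from 50 nM to 300 nM.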

Compound 4, half-maximal effective concentration: 220 nM
Compound 4: middle estimate off by 1.8-fold (0.26 log units), on the low side; the range from low to high includes it.
By their numbers in this assay, from the lowest: compound 3; then compounds 4, 1 and 2 (each within the scatter of the next).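

The two small non-aromatic rings are not interchangeable at this position: cyclopropyl in place of cyclobutyl gives a 2.4-fold higher number from compound 3 to compound 4 (0.39 log units; beyond the scatter) in this assay, a modest change for so small an exchange. Compound 4 also does not share the low number of compound 3, and it stays within the scatter of the compounds with aromatic groups, with a 1.2-fold lower number from compound 1 to compound 4 (0.07 log units; within the scatter) and a 1.6-fold lower number from compound 2 to compound 4 (0.20 log units; within the scatter), so a small non-aromatic ring on this nitrogen does not by itself give the lowest number; among these four, only cyclobutyl stands apart. Nothing available explains why the four-membered ring differs from the three-membered one.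

The compounds shown leave open whether cyclopentyl, or an open chain such as isopropyl, would match or pass cyclobutyl at this position. They also leave open whether a ring holding an oxygen atom, such as oxetanyl, would keep the number of compound 3.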